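Second chloro on two related cores

This account rests on a few compounds, and the source may have more. Where it says the series, first, only, none or still open, it means among the compounds named here.

Working notes on a short series tested in a functional assay on HCT-116 cells (Homo sapiens) for cytotoxicity, read by sulforhodamine B assay, with a stated time of 48 h; on this read-out higher numbers stand for weaker inhibition of growth and lower numbers for stronger inhibition of growth. Compound 1 `ClCc1cccc(Cn2cnc3ncnc(Cl)c32)c1` gives 5240 nM. Compound 2 `ClCc1cccc(Cn2cnc3c(Cl)ncnc32)c1` gives 3090 nM in this assay. Compounds 1 and 2 are built from the same atoms joined differently; the difference between the two cores is not broken down here, and their two values lie within the usual scatter of each other, so no order between them is drawn. Compound 3 `ClCc1cccc(Cn2cnc3c(Cl)nc(Cl)nc32)c1` gives 3090 nM in this assay. It arises from compound 2 by a single change, (chloro in place of hydrogen on an aromatic carbon), and the step is no change at the digits printed from compound 2 to compound 3 (within the scatter).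

Compound 4 `ClCc1cccc(Cn2cnc3nc(Cl)nc(Cl)c32)c1` has not yet been measured. It arises from compound 1 by chloro in place of hydrogen on an aromatic carbon. Among the compounds with values here, the place of the entering chloro is described in identical words for both pairs, so this is the same change already seen between compounds 2 and 3, and that pair is the only precedent available. For compound 4 the expectation in this assay is therefore a number close to that of compound 1, with the expected step being a 1.2-fold lower number from compound 1 to compound 4 (0.07 log units; within the scatter), because the measured precedent no change at the digits printed from compound 2 to compound 3 (within the scatter) showed no movement beyond the scatter. Compound 4 is estimated at 4500 nM in this assay, with a range of 2000 nM to 10000 nM expected to cover most repeat measurements. The expectation rests on a single precedent pair and carries the corresponding uncertainty.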

Compound 4, concentration for total growth inhibition: 1990 nM
For compound 4 the middle estimate is 2.3-fold (0.35 log units) above the measured one, and the stated range ends above it.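

In this assay, chloro in place of hydrogen on an aromatic carbon, between two ring nitrogen atoms, gives a 2.6-fold lower number from compound 1 to compound 4 (0.42 log units; beyond the scatter), a modest step that on its own stands clear of the noise, unlike the step seen on the other core. Read side by side, however, the two results do not separate, so the apparent contrast between the cores is not established: the same change on two cores in this assay, no change at the digits printed (within the scatter) from compound 2 to compound 3 and a 2.6-fold lower number (0.42 log units; beyond the scatter) from compound 1 to compound 4, 2.6-fold (0.42 log units) apart, within the scatter of two such steps. The change can therefore be carried from one core to the other without any measured sign that the core alters its outcome, but this does not show that the outcome is the same on both, since only these two pairs are available and a real difference of modest size could remain hidden in the scatter.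

The compounds shown leave open whether the response on the core of compound 1 would hold up on repeat measurement and whether it is specific to chloro. An amine, a methoxy group or a longer chain in place of the entering chloro could test on both cores whether the number moves at all with the group on that carbon, and whether the two cores then part.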